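Anilide series: amide aryl variation in rat paw edema

The source may report more compounds than this note shows. Statements on the series, on what has been measured and on what is new or still open speak of the compounds shown alone.

Measured so far:
compound 1, `COc1cc2c(cc1OC)C(CC(=O)Nc1ccc(Cl)cc1)CC2`: 63%
compound 2, `COc1cc2c(cc1OC)C(CC(=O)Nc1ccc(C)cc1)CC2`: 26%

In a functional assay on the whole organism (strain Wistar) for inhibition, with Rattus norvegicus as the target, read by paw edema, with a stated time of 2 h, at a dose of 100 mg/kg (on this read-out higher numbers stand for more inhibition at the one dose given (going by the name of the read-out) and lower numbers for less inhibition), compound 1 gives 63%, and compound 2 gives 26%. For the measured compounds named here, the one step between them, a number 37 percentage points lower from compound 1 to compound 2 (beyond the scatter), shows that a single change on the aryl group of the anilide can move the read-out a long way. Compound 2 stands lowest of the two numbers; the nearest value is that of compound 1.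

Compound 3, `COc1ccccc1NC(=O)CC1CCc2cc(OC)c(OC)cc21`, is not yet measured. It differs from compound 2 by 2-methoxyphenyl in place of 4-methylphenyl on an amide-type nitrogen. Going by the values given here, no measured step concerns a 2-methoxyphenyl group, so the only guidance is the size of the known step, which tells that the series is sensitive to the aryl group but not in which direction this change will act. Compound 3 is therefore expected to stay near compound 2, with wide uncertainty: the estimate is 30%, range 10% to 55%, which means an expected step of a number 4 percentage points higher from compound 2 to compound 3 (within the scatter).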

Compound 3, a percentage reported as inhibition, in the whole organism at one dose (the size of the read-out at that dose, not a potency): 16%
For compound 3 the middle estimate is 14 percentage points above the measured one; low and high end bracket the measured number.
By their numbers in this assay, from the lowest: compounds 3 and 2 (each within the scatter of the next); then compound 1.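

In this assay, the step of a number 10 percentage points lower from compound 2 to compound 3 (within the scatter) shows that 2-methoxyphenyl and 4-methylphenyl on the amide-type nitrogen cannot be told apart, despite the extra oxygen and hydrogen-bond acceptor counted for the entering group. The step of a number 47 percentage points lower from compound 1 to compound 3 (beyond the scatter) is large, so with the earlier step from compound 1 to compound 2 now joined by a second, 4-chlorophenyl stands apart from both other aryl groups, and compound 1 alone holds a high number in this set. Nothing measured on these compounds accounts for that separation.

Still open, on these data alone, is whether the high number of compound 1 belongs to chloro itself or to the wider aryl group. An unsubstituted phenyl, a 4-fluorophenyl or a pyridyl group on the same nitrogen would test this, while 4-methoxyphenyl would separate the methoxy group from its place.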